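Swapping Phenyl for Thiophen-2-yl in a Cytotoxic Series

This account rests on a few compounds, and the source may have more. Where it says the series, first, only, none or still open, it means among the compounds named here.

Among the measured compounds shown here, only two compounds have been measured so far. In a functional assay on SK-BR-3 cells (Homo sapiens) for cytotoxicity, read by resazurin assay, with a stated time of 72 h (on this read-out lower numbers stand for stronger inhibition and higher numbers for weaker inhibition), compound 1 `CCCCOC(=O)CCSC(=S)NCc1cccnc1` gives 4460 nM and compound 2 `S=C(NCc1cccnc1)SCCc1nnc(-c2ccccc2)o1` gives 580 nM on the same scale. Compound 2 therefore holds the lower number of the two, and the gap between them lies beyond the usual scatter of repeat measurements. The next compound, compound 3 `S=C(NCc1cccnc1)SCCc1nnc(-c2cccs2)o1`, keeps all of compound 2 except one group: thiophen-2-yl in place of phenyl on an aromatic carbon. The two measured compounds differ in more than one place, so nothing measured yet shows directly what this swap does. Both groups are single aromatic rings with no net charge, so compound 3 is expected to stay within the scatter of compound 2 at 580 nM in this assay with neither direction favoured. The estimate puts a 1.0-fold higher number from compound 2 to compound 3 (0.01 log units; within the scatter) within that scatter. Compound 3 is estimated at 600 nM (expected range 250 nM to 1500 nM).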

Compound 3, half-maximal inhibitory concentration: 1070 nM
Beside the measured number, compound 3's estimate is 1.8-fold (0.25 log units) below it; the measured number falls inside the stated range.
By their numbers in this assay, from the lowest: compounds 2 and 3 (each within the scatter of the next); then compound 1.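

Among the compounds shown here, exchanging phenyl for thiophen-2-yl on the five-membered aromatic ring with 2 nitrogen and 1 oxygen gives a 1.8-fold higher number from compound 2 to compound 3 (0.27 log units; within the scatter) in this assay, the first direct reading of a change at this place. A six-membered aromatic ring of carbon only and a five-membered aromatic ring with one sulfur therefore cannot be told apart here, so this place accepts either ring, and the extra hydrogen-bond acceptor counted for thiophen-2-yl brings no difference beyond repeat-to-repeat variation. Nothing available explains why the two rings read alike.

On these data alone, both rings are single aromatic groups with no net charge, so it remains open whether this place would also accept a group of a different kind, such as a methyl, a cyclohexyl, an amine or a carboxylic acid. As far as these compounds go, it is equally open whether a phenyl carrying a chlorine or a methoxy group, or a pyridine ring, would shift the number beyond that variation in either direction.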